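Fluoro to hydrogen on the aromatic ring of compound 3

The source may hold more compounds than are shown below. What is called first, only, known or untested is meant among the compounds shown, and "the series" means these compounds.

Among the compounds with values here, in an assay on CHO cells for displacement of a labelled ligand from adenosine receptor A1 (Homo sapiens), read by scintillation counting, with a stated time of 3 h (on this read-out lower numbers stand for stronger inhibition and higher numbers for weaker inhibition), compound 3 `CC(C)n1cc2c(Cl)nc(NC(=O)c3ccc(F)cc3)nc2n1` gives 3400 nM, the lowest number among the three measured so far; compound 1 `CC(C)(C)Cn1cc2c(Cl)nc(NC(=O)c3ccccc3)nc2n1` gives 11000 nM and compound 2 `CC(C)n1cc2c(Cl)nc(NC(=O)c3ccc(C(F)(F)F)cc3)nc2n1` gives 13800 nM. Compound 4 `CC(C)n1cc2c(Cl)nc(NC(=O)c3ccccc3)nc2n1` differs from compound 3 by hydrogen in place of fluoro on an aromatic carbon. Within the data shown here, the only measured step that touches this place is a 4.1-fold lower number from compound 2 to compound 3 (0.61 log units; beyond the scatter), a change toward a smaller substituent. Compound 1 carries plain phenyl but also a different group on the core, so its value bears only loosely on the step. Taking the fluoro away is expected to move the number up modestly, a 1.6-fold higher number from compound 3 to compound 4 (0.21 log units; within the scatter). Compound 4 is therefore estimated at 5500 nM, with a range from 2200 nM to 14000 nM in this assay.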

Compound 4, inhibition constant: 19600 nM
The estimate for compound 4 lay 3.6-fold (0.55 log units) below the measured number; measured number outside the range, above it.
By their numbers in this assay, from the lowest: compound 3; then compounds 1, 2 and 4 (each within the scatter of the next).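

In this assay the change from 4-fluorophenyl to phenyl gives a 5.8-fold higher number from compound 3 to compound 4 (0.76 log units; beyond the scatter) at this place, so the lead of compound 3 rests on the fluoro. With a 1.4-fold higher number from compound 2 to compound 4 (0.15 log units; within the scatter) as well, hydrogen and trifluoromethyl are not separated here, and of the three groups only fluoro gives the lower number. With plain phenyl in place, a 1.8-fold higher number from compound 1 to compound 4 (0.25 log units; within the scatter) leaves isopropyl and neopentyl on the aromatic nitrogen unseparated too.

On these data alone, whether a methoxy group or an amine at this place would match fluoro remains open. No measurement on hand accounts for the fluoro result.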